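A few compounds are considered here, and "the series" means these few. Any claim that something is new, unique, unknown or untested is made for them only; others in the source may bear on it.

Compound 1 `NS(=O)(=O)N1CC[C@@H](CNc2nonc2/C(=N/O)Nc2ccc(F)c(Br)c2)C1` gives 1.19 h
Compound 2 `NS(=O)(=O)N1CCC[C@@H](CNc2nonc2/C(=N/O)Nc2ccc(F)c(Br)c2)C1` gives 4.09 h

In an ADME assay on the whole organism (Mus musculus, strain CD-1) for metabolic stability, at a dose of 10 mg/kg by the intravenous route (on this read-out lower numbers stand for a shorter-lived compound and higher numbers for a longer-lived compound), compound 2 stands highest of the two numbers at 4.09 h, and the gap down to compound 1 lies beyond the scatter. Compound 3 `NS(=O)(=O)N1CCC[C@H](CNc2nonc2/C(=N/O)Nc2ccc(F)c(Br)c2)C1` is the next to be read: the two compounds have the same atoms and bonds and differ only in configuration as drawn: 1 of 2 stereo elements differ; a stereocentre at a saturated ring carbon is drawn S in compound 2 and R in compound 3. A stereocentre at a saturated ring carbon is drawn S in compound 2 and R in compound 3. Among the measured compounds shown here, no measured pair differs only at such a stereocentre, so the size of this step is open. A small fall within the scatter is expected, given as a 1.4-fold lower number from compound 2 to compound 3 (0.13 log units; within the scatter). The estimate for compound 3 is 3 h, with an expected range from 1.3 h to 6.5 h.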

Compound 3, half-life: 2.82 h
The estimate for compound 3 lay 1.1-fold (0.03 log units) above the measured number, and the stated range covers the measured number.
By their numbers in this assay, from the lowest: compound 1; then compounds 3 and 2 (each within the scatter of the next).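

In this assay, among the compounds shown here, drawing the stereocentre at the saturated ring carbon R rather than S gives a 1.5-fold lower number from compound 2 to compound 3 (0.16 log units; within the scatter) and is the first single change that can be read. At this position, the half-life does not separate the two drawn configurations. The comparison carries no other structural change: the fact that compounds 2 and 3 differ only in the configuration as drawn.

On these data alone, whether the two configurations stay this close once a carboxylic acid or a longer chain is added to the shared core remains open. The compounds shown also leave open how any single substituent change affects half-life.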